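Replacing a Chain Carbon with Oxygen: Expected Stability

This account rests on a few compounds, and the source may have more. Where it says the series, first, only, none or still open, it means among the compounds named here.

In an ADME assay on microsomes from liver (Homo sapiens) for metabolic stability, using NADPH, with a stated time of 10 min (on this read-out lower numbers stand for a less stable compound and higher numbers for a more stable compound), compound 1 `CCCCc1nc(=O)c(S(=O)(=O)c2ccc(-c3ccc(F)cc3)cc2)c(O)n1-c1c(OC)cccc1OC` gives 100% and compound 2 `CCCCc1nc(=O)c(S(=O)(=O)c2ccc(-c3ccc(F)nc3)cc2)c(O)n1-c1c(OC)cccc1OC` gives 100%. Compound 3 `COc1cccc(OC)c1-n1c(CCC(C)C)nc(=O)c(S(=O)(=O)c2ccc(-c3ccc(F)nc3)cc2)c1O` gives 89%, the lowest of the three numbers. The two measured steps are no change at the digits printed from compound 1 to compound 2 (within the scatter) and a number 11 percentage points lower from compound 2 to compound 3 (beyond the scatter). Compound 4 `COc1cccc(OC)c1-n1c(COC(C)C)nc(=O)c(S(=O)(=O)c2ccc(-c3ccc(F)nc3)cc2)c1O` differs from compound 3 by isopropoxy in place of isobutyl on a saturated chain carbon bound to an aromatic carbon. Neither measured step puts an oxygen into the chain, so neither bears directly on this change; the nearest is the modest chain change a number 11 percentage points lower from compound 2 to compound 3 (beyond the scatter). With only a chain alteration of similar size as guidance, the step is expected to stay small, a number 1 percentage points higher from compound 3 to compound 4 (within the scatter). Compound 4 is therefore estimated at 90%, within a range from 75% to 100%.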

Compound 4, percent of the compound remaining: 84%
Compound 4: middle estimate off by 6 percentage points, on the high side, and the stated range covers the measured number.
By their numbers in this assay, from the lowest: compounds 4 and 3 (each within the scatter of the next); then compounds 1 and 2 (each within the scatter of the next).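

In this assay, the oxygen in the chain barely registers against the all-carbon isobutyl group (a number 5 percentage points lower from compound 3 to compound 4 (within the scatter)) and the two compounds cannot be told apart. Against propyl, the same isopropoxy group gives a clearer step (a number 16 percentage points lower from compound 2 to compound 4 (beyond the scatter)), so at this position compound 4 sits with compound 3 and not with compound 2. As far as these compounds go, whether an amine in the same chain place, or a longer chain holding the oxygen, would keep or lower the number remains open. Nothing measured here explains this result.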